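Hydroxy for Dimethylamino in an Interleukin-2 Inhibitor Series

The source may report more compounds than this note shows. Statements on the series, on what has been measured and on what is new or still open speak of the compounds shown alone.

Compound 1 `Cn1c(Cc2nn(CCCO)c(=O)c3ccccc23)nnc1SCC(=O)Nc1ccc(Cl)cc1Cl`, a limit: > 30000 nM
Compound 2 `CN(C)CCCn1nc(Cc2nnc(SCC(=O)Nc3ccc(Cl)cc3Cl)n2C)c2ccccc2c1=O`, a limit: > 30000 nM
Compound 3 `CN(C)CCCn1nc(Cc2nnc(SCCCCCCCC(=O)Nc3ccc(Cl)cc3Cl)n2C)c2ccccc2c1=O`, a limit: > 30000 nM

Among the compounds with values here, in an assay on NK92 cells for inhibition of interleukin-2 (Homo sapiens), read by AlphaScreen, with stated times of 30 min and 1 h (a lower number here means a stronger inhibitor, a higher number a weaker inhibitor), every value so far is a limit of the assay rather than a number, as all three sit at the limit of > 30000 nM in this assay, at which 3 of the 3 values shown sit. Compound 1 arises from compound 2 through (hydroxy in place of dimethylamino on a saturated chain carbon, three bonds along the chain from an aromatic nitrogen). The size of that step, a step that the two limits leave unreadable from compound 2 to compound 1, cannot be read because both compounds sit at the limit of > 30000 nM in this assay, at which 3 of the 3 values shown sit. How the core of compound 3 differs from that of compound 2 is not broken down here. Compound 4 `Cn1c(Cc2nn(CCCO)c(=O)c3ccccc23)nnc1SCCCCCCCC(=O)Nc1ccc(Cl)cc1Cl` arises from compound 3 through the same change, (hydroxy in place of dimethylamino on a saturated chain carbon, three bonds along the chain from an aromatic nitrogen). Given that compound 3 sits at the limit of > 30000 nM in this assay, at which 3 of the 3 values shown sit, and the earlier step that the two limits leave unreadable from compound 2 to compound 1 left no readable shift, the expected step is a step that the limit leaves unreadable from compound 3 to compound 4, essentially none. Compound 4 is therefore estimated at 60000 nM, expected between 25000 nM and 300000 nM.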

Compound 4, half-maximal inhibitory concentration: > 30000 nM
Compound 4: a limit, no number; the forecaster's own chance of this, stated with the estimate: 90%; the middle value lies beyond the limit too.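

The step from compound 3 to compound 4 cannot be read, because both values are limits and not numbers: the limit of > 30000 nM in this assay, at which 4 of the 4 values shown sit.

The compounds shown leave open whether hydroxy in place of dimethylamino changes inhibition at all in this assay.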